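The source may hold more compounds than are shown below. What is called first, only, known or untested is meant among the compounds shown, and "the series" means these compounds.

In a functional assay on the whole organism (Tail, strain ICR) with Mus musculus as the target, in the tail flick test, with a stated time of 120 min, at a dose of 25 umol/kg by the oral route (a higher number here means a stronger effect of the compound at the dose given, a lower number a weaker effect), compound 1 `O=C(O)[C@@H]1CCCN1C(=O)CN(c1nc(Cl)nc2[nH]cnc12)C1CC1` gives 23.6%, and compound 2 `O=C(CN(c1nc(Cl)nc2[nH]cnc12)C1CC1)N[C@@H](CO)C(=O)O` gives 39%. Within the data shown here, the single measured step, a number 15.4 percentage points higher from compound 1 to compound 2 (beyond the scatter), puts (1-carboxy-2-hydroxyethyl)amino in place of 2-carboxypyrrolidin-1-yl on the carbonyl carbon. Among the measured compounds shown here, of the two numbers so far compound 2 stands highest, with compound 1 the only neighbour and lower by that step. Compound 3 `CSCC[C@H](NC(=O)CN(c1nc(Cl)nc2[nH]cnc12)C1CC1)C(=O)O` differs from compound 2 by (methylsulfanyl)methyl in place of hydroxy on a saturated chain carbon, two bonds along the chain from an amide-type nitrogen and a carbonyl carbon. For the measured compounds named here, no measured step alters only this part of the amino-acid fragment; the one step known was modest and exchanged the whole fragment bound to the carbonyl carbon, so it gives no direction for the present change. In this assay a step within the scatter, a number 1 percentage points lower from compound 2 to compound 3 (within the scatter), is therefore expected. For compound 3 the estimate is 38%, with a range from 22% to 54%.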

Compound 3, a percentage reported as activity, at one dose (the size of the read-out at that dose, not a potency): 5.67%
Compound 3: the middle estimate sits 32.3 percentage points above what was measured; measured number below the stated range.
By their numbers in this assay, from the lowest: compound 3; then compound 1; then compound 2.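

In this assay, this position on the amino-acid fragment matters by itself: with (methylsulfanyl)methyl in place of hydroxy on a saturated chain carbon, two bonds along the chain from an amide-type nitrogen and a carbonyl carbon, the read-out shows a number 33.3 percentage points lower from compound 2 to compound 3 (beyond the scatter) and the step counts as large. The earlier step, a number 15.4 percentage points higher from compound 1 to compound 2 (beyond the scatter) and modest, exchanged the whole fragment bound to the carbonyl carbon, so it could not show what a change at this one place does. No measurement at hand explains the size of the new step.

The compounds shown do not separate the effect of removing the hydroxy from that of adding the sulfur or the longer chain. An all-carbon chain such as propyl at this position, or a chain ending in an amine, would help to tell these apart.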